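Cytotoxicity of an aminocyclopentanediol series: a trifluoropropyl extension

The source may report more compounds than this note shows. Statements on the series, on what has been measured and on what is new or still open speak of the compounds shown alone.

Measured compounds:
compound 1, `Nc1nc(Cl)c(-c2ncco2)c(N[C@@H]2C[C@H](CO)[C@@H](O)[C@H]2O)n1`, > 25000 nM
compound 2, `Nc1nc(Cl)c(-c2nc3ccc(F)cc3s2)c(N[C@@H]2C[C@H](CO)[C@@H](O)[C@H]2O)n1`, > 25000 nM
compound 3, `CNc1nc(C)c(-c2nc3ccccc3s2)c(N[C@@H]2C[C@H](CO)[C@@H](O)[C@H]2O)n1`, > 25000 nM

These three compounds were assessed in an ADME assay on cells (Homo sapiens) for cytotoxicity, read by polymerase chain reaction, with a stated time of 3 days; a lower number here means that less compound is tolerated, a higher number that more compound is tolerated. For compound 1 the result is a limit of the assay, > 25000 nM, not a number. Compound 2 likewise gives only a limit, > 25000 nM. Compound 3 also returns a limit, > 25000 nM, so its standing among the values shown cannot be ranked: all three sit at the same limit, as the data show, (the limit of > 25000 nM in this assay, at which 3 of the 3 values shown sit).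

The untested compound 4, `Cc1nc(NCCCC(F)(F)F)nc(N[C@@H]2C[C@H](CO)[C@@H](O)[C@H]2O)c1-c1nc2ccccc2s1`, is compound 3 with one alteration: 3,3,3-trifluoropropyl in place of hydrogen on a saturated chain carbon bound to a nitrogen on an aromatic ring. Among the measured compounds shown here, no step between measured compounds is available to size this change. Because every value shown sits at the limit, (the limit of > 25000 nM in this assay, at which 3 of the 3 values shown sit), the expectation for compound 4 in this assay is that it remains near that limit, with a step of a number no higher from compound 3 to compound 4 (the limit leaves the size open) of no size beyond the scatter, in either direction. Compound 4 is therefore estimated at 25000 nM, within a range from 10000 nM to 60000 nM.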

Compound 4, half-maximal cytotoxic concentration: 3000 nM
Estimate against measurement, compound 4: 8.3-fold (0.92 log units) above, outside the stated range (below it).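

In this assay, 3,3,3-trifluoropropyl in place of hydrogen on a saturated chain carbon bound to a nitrogen on an aromatic ring gives an at least 8.3-fold lower number from compound 3 to compound 4 (0.92 log units; beyond the scatter). Compound 3 gives only a limit, > 25000 nM, so the step has a lower bound but no upper one. Among the compounds shown here, the earlier compounds could not show that the number in this assay responds to any change, whereas this position does respond, and compound 4 is the only compound here with a value that is not a limit: the limit of > 25000 nM in this assay, at which 3 of the 4 values shown sit.

Going by these compounds, whether a plain propyl chain, a shorter ethyl chain, a longer chain or a chain ending in an amine at this nitrogen would give a similar number remains open. Also open, on these data alone, is whether the same extension would lower the number on the cores of compound 1 and compound 2.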